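Swapping methoxy for formyl on the pendant phenyl ring

The compounds below may be only part of what the source reports. "The series", "measured", "known", "first", "only" and "open" are said of these compounds alone.

Of the compounds shown here, three built on one shared core have been measured in a functional assay on CCRF-CEM cells (Homo sapiens) for inhibition, read by sulforhodamine B assay, with a stated time of 48 h, tested at 10 uM; a higher number here means more inhibition at the concentration tested (going by the name of the read-out), a lower number less inhibition. Compound 1 `Brc1cn2ccnc2c(-c2ccc3ncn(C4CCCCC4)c3c2)n1` gives 7.68%. Compound 2 `c1ccc(-c2cn3ccnc3c(-c3ccc4ncn(C5CCCCC5)c4c3)n2)cc1` gives 81.3%, and compound 3 `COc1ccc(-c2cn3ccnc3c(-c3ccc4ncn(C5CCCCC5)c4c3)n2)cc1` gives 93.3%, which is the highest of the three numbers; compound 2 lies closest to it, compound 1 furthest away. The measured steps show a number 73.6 percentage points higher from compound 1 to compound 2 (beyond the scatter) and a number 85.6 percentage points higher from compound 1 to compound 3 (beyond the scatter), both large, while a number 12 percentage points higher from compound 2 to compound 3 (beyond the scatter) is modest.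

Compound 4 `O=Cc1ccc(-c2cn3ccnc3c(-c3ccc4ncn(C5CCCCC5)c4c3)n2)cc1` is not yet measured. It differs from compound 3 by formyl in place of methoxy on an aromatic carbon. Among the compounds with values here, only one measured step touches this position, a number 12 percentage points higher from compound 2 to compound 3 (beyond the scatter), and it is modest, so the substituent at that place seems to shift the read-out little once a phenyl ring is present. Within the data shown here, no measured compound carries a formyl group, so nothing shows how that group behaves. The expectation is therefore a small change, in either direction, with the estimated step being a number 11.3 percentage points lower from compound 3 to compound 4 (beyond the scatter). Compound 4 is expected to give about 82%, in the range 60% to 95% in this assay.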

Compound 4, a percentage reported as inhibition, at one concentration (the size of the read-out at that concentration, not a potency): 77.9%
Beside the measured number, compound 4's estimate is 4.1 percentage points above it; the measured number falls inside the stated range.
By their numbers in this assay, from the lowest: compound 1; then compounds 4 and 2 (each within the scatter of the next); then compound 3.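

Formyl in place of methoxy gives a number 15.4 percentage points lower from compound 3 to compound 4 (beyond the scatter) in this assay even though the two groups have the same heavy-atom count, while formyl in place of hydrogen gives a number 3.4 percentage points lower from compound 2 to compound 4 (within the scatter) and so does not separate compound 4 from the unsubstituted phenyl of compound 2. Among these three phenyl compounds, the extra inhibition therefore belongs to methoxy and does not come from simply having any group at this place on the ring. The aromatic ring itself still matters far more, with a number 70.2 percentage points higher from compound 1 to compound 4 (beyond the scatter) when 4-formylphenyl replaces bromo, and no supporting evidence explains why methoxy and formyl differ.

From the compounds shown here alone, it remains open how an amine, a hydroxyl, a carboxylic acid or a longer ether such as ethoxy would behave at this place. Each compound also has a reading at only one concentration, so these numbers do not show how potency compares.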